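This account rests on a few compounds, and the source may have more. Where it says the series, first, only, none or still open, it means among the compounds named here.

The shared core places a saturated chain carbon between an oxygen on an unsaturated carbon and a triple-bonded carbon, and the compounds differ in what sits on that carbon and at the ends of the chains. Compound 1 `CCCC(C#CC(=O)OC)O/C=C/C(=O)OC` carries a propyl group on that carbon. In a functional assay on SW1573 cells (Homo sapiens) for antiproliferative activity, read by sulforhodamine B assay, with a stated time of 48 h (on this read-out higher numbers stand for weaker inhibition of growth and lower numbers for stronger inhibition of growth), compound 1 gives 320 nM, the lowest of the two numbers recorded. Compound 3 `Cc1ccc(S(=O)(=O)C#CC(O/C=C/S(=O)(=O)c2ccc(C)cc2)C(C)C)cc1` gives 3200 nM in this assay, a gap beyond the usual scatter of repeated runs. Compound 2 `CC1CCC(C(C)C)C(OC(=O)C#CC(O/C=C/C(=O)OC2CC(C)CCC2C(C)C)C(C)C)C1` reaches only a limit in this assay, > 100000 nM, and so contributes no number (the limit of > 100000 nM in this assay, at which 1 of the 3 values shown sits).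

Compound 4 `COC(=O)C#CC(O/C=C/C(=O)OC)C1CCCCC1` differs from compound 1 at that saturated chain carbon alone: cyclohexyl in place of propyl on a saturated chain carbon bound to an oxygen on an unsaturated carbon and a triple-bonded carbon. Going by the values given here, no pair of measured compounds differs by just this change, so the weight of the cyclohexyl group at this position is untested here. The step from compound 1 to compound 4 is expected to be small, a 1.6-fold higher number from compound 1 to compound 4 (0.19 log units; within the scatter), without a direction that exceeds the scatter. Compound 4 is estimated at 500 nM, within a range of 150 nM to 2500 nM.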

Compound 4, concentration for 50% growth inhibition: 2100 nM
Compound 4: middle estimate off by 4.2-fold (0.62 log units), on the low side; the range from low to high includes it.
By their numbers in this assay, from the lowest: compound 1; then compounds 4 and 3 (each within the scatter of the next). At a limit, above all of these: compound 2.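

Going by these compounds alone, the step of a 6.6-fold higher number from compound 1 to compound 4 (0.82 log units; beyond the scatter) gives the first direct reading at this position, since no earlier pair of compounds differed in one place only. With the methyl ester ends held constant, the saturated chain carbon is not indifferent to its substituent: cyclohexyl in place of propyl weakens growth inhibition by more than the usual scatter. This single step does not establish why the number rises, and no measurement shown here bears on the cause.

A single pair cannot separate the presence of the ring from the larger count of carbons in cyclohexyl, so an open chain such as hexyl at this carbon would be informative. From the compounds shown here alone, it also remains open how a phenyl ring, or a chain ending in an amine or a carboxylic acid, would fare at this position.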